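A few compounds are considered here, and "the series" means these few. Any claim that something is new, unique, unknown or untested is made for them only; others in the source may bear on it.

Compound 1 `O=C(CCC(=O)c1ccccc1)Nc1nc2ccc(Cl)cc2s1` sits at the upper end of the three numbers in hand: in a functional assay on the whole organism with Mus musculus as the target, in the maximal electroshock model, with a stated time of 4 h (on this read-out lower numbers stand for an effect already at smaller amounts and higher numbers for an effect only at larger amounts of compound), compound 1 gives 300 mg/kg, level with compound 2 `O=C(CCC(=O)c1ccccc1)Nc1nc2ccc(Br)cc2s1`, which gives 300 mg/kg. Compound 3 `COc1ccc2nc(NC(=O)CCC(=O)c3ccccc3)sc2c1` gives 30 mg/kg. The swap no change at the digits printed from compound 1 to compound 2 (within the scatter) is a halogen for a halogen; the swap a 10-fold lower number from compound 1 to compound 3 (1.00 log units; beyond the scatter) replaces the halogen with a group carrying an acceptor. Compound 4 `CC(=O)c1ccc2nc(NC(=O)CCC(=O)c3ccccc3)sc2c1` carries the change (acetyl in place of chloro on an aromatic carbon). Among the compounds with values here, no measured step involves acetyl. Of the steps known, the methoxy entry, a 10-fold lower number from compound 2 to compound 3 (1.00 log units; beyond the scatter), is the closer analogy in kind, a halogen replaced by an acceptor-bearing group, and a lowering of the number in this assay is therefore expected, though a smaller one than the methoxy step, with the unchanged halogen swap as a caution. The expected step is a 3.0-fold lower number from compound 1 to compound 4 (0.48 log units; beyond the scatter), and compound 4 is estimated at 100 mg/kg, from 30 mg/kg to 300 mg/kg.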

Compound 4, minimum effective dose: 100 mg/kg
Compound 4: the middle estimate sits on the measured number at the digits printed, and the stated range covers the measured number.
By their numbers in this assay, from the lowest: compound 3; then compound 4; then compounds 1 and 2 (each within the scatter of the next).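

In this assay acetyl on this aromatic carbon gives a 3.0-fold lower number from compound 1 to compound 4 (0.48 log units; beyond the scatter) and a 3.0-fold lower number from compound 2 to compound 4 (0.48 log units; beyond the scatter) so the lowering from the halogen compounds is no longer tied to methoxy alone. Acetyl does not match methoxy either, with a 3.3-fold higher number from compound 3 to compound 4 (0.52 log units; beyond the scatter) at the same place, so the two non-halogen groups are not interchangeable here. Nothing available speaks to the cause of these steps. Open, from the compounds shown here alone, is whether an amine or a carboxylic acid at this place would fall with the halogen compounds or with compound 3, and how a longer acyl chain would compare with acetyl.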